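Swapping the ethyl for trifluoromethyl on the aryl ether oxygen

A few compounds are considered here, and "the series" means these few. Any claim that something is new, unique, unknown or untested is made for them only; others in the source may bear on it.

Of the compounds shown here, three sharing one core have so far been tested in a functional assay for antagonist activity at Alpha-1A adrenergic receptor (Oryctolagus cuniculus); a lower number here means tighter binding, a higher number weaker binding. Compound 1 `COc1ccccc1N1CCN(CCCNc2ncccc2C(=O)N(C)C)CC1` gives 1.59 nM, compound 2 `CN(C)C(=O)c1cccnc1NCCCN1CCN(c2ccccc2C#N)CC1` gives 2 nM, and compound 3 `CCOc1ccccc1N1CCN(CCCNc2ncccc2C(=O)N(C)C)CC1` gives 0.501 nM. Compound 3 therefore has the lowest number of the three: the step of a 3.2-fold lower number from compound 1 to compound 3 (0.50 log units; beyond the scatter) and the step of a 4.0-fold lower number from compound 2 to compound 3 (0.60 log units; beyond the scatter) both lie beyond the scatter, while the step of a 1.3-fold higher number from compound 1 to compound 2 (0.10 log units; within the scatter) does not.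

Compound 4 `CN(C)C(=O)c1cccnc1NCCCN1CCN(c2ccccc2OC(F)(F)F)CC1` differs from compound 3 by trifluoromethyl in place of ethyl on an oxygen on an aromatic ring. For the measured compounds named here, no measured step shows this exact exchange. The nearest guide is that lengthening the group on the oxygen from compound 1 to compound 3 lowered the number modestly, and that the ether of compound 3 beat the cyano of compound 2 by a similar margin. Trifluoromethyl occupies the same position as ethyl, so compound 4 is expected to stay close to compound 3, with at most a small rise in this assay, an expected step of a 2.0-fold higher number from compound 3 to compound 4 (0.30 log units; within the scatter). The estimate for compound 4 is 1 nM, within a range of 0.3 nM to 3 nM.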

Compound 4, dissociation constant: 3.16 nM
Estimate against measurement, compound 4: 3.2-fold (0.50 log units) below; measured number above the stated range.
By their numbers in this assay, from the lowest: compound 3; then compounds 1, 2 and 4 (each within the scatter of the next).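

In this assay the low number of compound 3 does not carry over when fluorine replaces the hydrogens of the group on the oxygen: the change shows a 6.3-fold higher number from compound 3 to compound 4 (0.80 log units; beyond the scatter), so ethyl and trifluoromethyl are not interchangeable on this oxygen on an aromatic ring. Trifluoromethoxy instead falls in with the other two groups, with a 2.0-fold higher number from compound 1 to compound 4 (0.30 log units; within the scatter) and a 1.6-fold higher number from compound 2 to compound 4 (0.20 log units; within the scatter), leaving ethoxy as the only group of the four that stands apart. Nothing measured here indicates what lies behind this difference.

Going by these compounds, whether a longer chain such as propyl, or a branched isopropyl, on the same oxygen would hold or lower the number of compound 3 remains open, as does where difluoromethyl would fall. An amine or a hydroxyl group in place of the whole ether is also an open case.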